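Swapping the aryl group on the piperazine nitrogen

The source may report more compounds than this note shows. Statements on the series, on what has been measured and on what is new or still open speak of the compounds shown alone.

Among the compounds with values here, compound 2 `N#Cc1ccc(N2CCN(C(=S)SCc3ccc(C(=O)Nc4ccccc4N)cc3)CC2)cc1` is the stronger of the two compounds measured so far: in a functional assay on HeLa cells (Homo sapiens) for antiproliferative activity, read by CCK-8 assay, with a stated time of 72 h, tested at 2 uM (a lower number here means a weaker effect, a higher number a stronger effect of the compound at the concentration tested), compound 2 gives 71.6%, while compound 1 `COc1ccc(N2CCN(C(=S)SCc3ccc(C(=O)Nc4ccccc4N)cc3)CC2)cc1` gives 39.4%. Within the data shown here, the one step between them, a number 32.2 percentage points higher from compound 1 to compound 2 (beyond the scatter), shows that the group on the aromatic ring attached to the ring nitrogen shapes the read-out strongly. Compound 3 `Nc1ccccc1NC(=O)c1ccc(CSC(=S)N2CCN(c3ncccn3)CC2)cc1` is not yet measured; it differs from compound 2 by pyrimidin-2-yl in place of 4-cyanophenyl on an amine nitrogen in a ring. Among the measured compounds shown here, no measured step matches this change, since only the substituent on that ring has been varied so far, not the ring itself. For the measured compounds named here, the large size of the one known step suggests the read-out can move far in either direction. On balance a drop of moderate size is expected, a number 21.6 percentage points lower from compound 2 to compound 3 (beyond the scatter), with wide uncertainty. Compound 3 is therefore estimated at 50%, within a range from 25% to 75%.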

Compound 3, a percentage reported as inhibition, at one concentration (the size of the read-out at that concentration, not a potency): 52.2%
Estimate against measurement, compound 3: 2.2 percentage points below; low and high end bracket the measured number.
By their numbers in this assay, from the lowest: compound 1; then compound 3; then compound 2.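

Within the data shown here, this is the first change to the ring on the amine nitrogen itself, rather than to a group that ring carries, and in this assay its direction depends on the group it replaces. Exchanging 4-cyanophenyl for pyrimidin-2-yl gives a number 19.4 percentage points lower from compound 2 to compound 3 (beyond the scatter), whereas exchanging 4-methoxyphenyl for it gives a number 12.8 percentage points higher from compound 1 to compound 3 (beyond the scatter). A ring with two nitrogen atoms therefore keeps a clear effect at this place, with compound 3 lying between compound 1 and compound 2, and nothing available explains this order.

From the compounds shown here alone, it remains open how an unsubstituted phenyl or a pyridin-2-yl group, with one ring nitrogen, would read at this place. Also open, going by these compounds, is whether a nitrile on the pyrimidin-2-yl ring would raise the number.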